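Chloro to methoxy on the carbonyl-bound phenyl ring

The compounds below may be only part of what the source reports. "The series", "measured", "known", "first", "only" and "open" are said of these compounds alone.

In an assay on MDA-MB-231 cells for binding affinity to C-X-C chemokine receptor type 4 (Homo sapiens), read by immunofluorescence and microscopy, with stated times of 10 min and 30 min (on this read-out higher numbers stand for an effect only at larger amounts of compound and lower numbers for an effect already at smaller amounts), compound 3 `Cc1ccc(S(=O)(=O)NCc2ccc(CNC(=O)c3cccc(Cl)c3)cc2)cc1` stands as the higher of the two numbers obtained: compound 3 gives 100 nM, whereas compound 2 `Cc1ccc(S(=O)(=O)NCc2ccc(CNC(=O)c3ccccc3Cl)cc2)cc1` gives 10 nM, the step being a 10-fold higher number from compound 2 to compound 3 (1.00 log units; beyond the scatter). Compound 1 `Cc1ccc(S(=O)(=O)NCc2ccc(CNC(=O)c3ccccc3)cc2)cc1` gives > 1000 nM, which is a limit of this assay and not a number (the limit of > 1000 nM in this assay, at which 1 of the 3 values shown sits). Compound 4 `COc1ccccc1C(=O)NCc1ccc(CNS(=O)(=O)c2ccc(C)cc2)cc1` differs from compound 3 in one place: 2-methoxyphenyl in place of 3-chlorophenyl on a carbonyl carbon. The step that bears most directly on this change is a 10-fold higher number from compound 2 to compound 3 (1.00 log units; beyond the scatter), while an at least 100-fold lower number from compound 1 to compound 2 (2.00 log units; beyond the scatter) and an at least 10-fold lower number from compound 1 to compound 3 (1.00 log units; beyond the scatter) show that a substituent on that ring lowers the number wherever it sits. Compound 4 is therefore expected to give a lower number than compound 3, a step of a 3.3-fold lower number from compound 3 to compound 4 (0.52 log units; beyond the scatter). Compound 4 is estimated at 30 nM, between 5 nM and 300 nM.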

Compound 4, effective concentration (reported as EC, without a stated level of effect): 100 nM
Beside the measured number, compound 4's estimate is 3.3-fold (0.52 log units) below it, and the stated range covers the measured number.
By their numbers in this assay, from the lowest: compound 2; then compounds 3 and 4 (each within the scatter of the next). At a limit, above all of these: compound 1.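

In this assay, 2-methoxyphenyl and 3-chlorophenyl on the carbonyl carbon cannot be told apart: no change at the digits printed from compound 3 to compound 4 (within the scatter). Methoxy in place of chloro on an aromatic carbon does not keep the low number of compound 2, so that low number depends on the group and not on the ring position alone: a 10-fold higher number from compound 2 to compound 4 (1.00 log units; beyond the scatter). Methoxy in place of hydrogen still registers, an at least 10-fold lower number from compound 1 to compound 4 (1.00 log units; beyond the scatter), though that step rests on a limit and not a number: the limit of > 1000 nM in this assay, at which 1 of the 4 values shown sits.

From the compounds shown here alone, whether an amine or a carboxylic acid on that ring could match compound 2 stays open. The compounds shown give no cause for the gap between compound 2 and compound 4.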